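A few compounds are considered here, and "the series" means these few. Any claim that something is new, unique, unknown or untested is made for them only; others in the source may bear on it.

Compound 1 `COCCOC(=O)c1ccc(F)c(C(=O)Nc2cccc(-c3cc(C(=O)Nc4ccncc4F)ccc3CN)c2)c1`: in an assay on cells for inhibition of Rho-associated protein kinase 2 (Homo sapiens), read by radiometric assay and 33P incorporation, in the presence of a further agent that is not named here (a lower number here means a stronger inhibitor, a higher number a weaker inhibitor), compound 1 gives 2.2 nM.
Compound 3 `COC(=O)c1ccc(C(=O)Nc2cccc(-c3cc(C(=O)Nc4ccncc4F)ccc3CN)c2)cc1`: in this assay compound 3 gives 3.1 nM.
Compound 2 `NCc1ccc(C(=O)Nc2ccncc2F)cc1-c1cccc(C(=O)OCC2CCCO2)c1`: in this assay compound 2 gives 49 nM.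

Compound 2 holds the highest of the three numbers in this assay; its gaps to compound 3 and to compound 1 both lie beyond the scatter, so compound 2 is the weakest of the three. The step from compound 2 leads to compound 4 `NCc1ccc(C(=O)Nc2ccncc2F)cc1-c1cccc(C(=O)Nc2ccccc2)c1`, with the change (anilino in place of (oxolan-2-yl)methoxy on a carbonyl carbon). Compounds 1 and 3, which carry an amide to an aromatic ring at the comparable position, sit well below compound 2, so a move toward the lower numbers is expected for compound 4. The expected step of a 4.9-fold lower number from compound 2 to compound 4 (0.69 log units; beyond the scatter) is beyond the scatter. Compound 4 is estimated at 10 nM, with a range from 3 nM to 40 nM.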

Compound 4, half-maximal inhibitory concentration: 31 nM
Compound 4: the middle estimate sits 3.1-fold (0.49 log units) below what was measured; the measured number falls inside the stated range.
By their numbers in this assay, from the lowest: compounds 1 and 3 (each within the scatter of the next); then compounds 4 and 2 (each within the scatter of the next).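

In this assay, anilino in place of (oxolan-2-yl)methoxy on a carbonyl carbon gives a 1.6-fold lower number from compound 2 to compound 4 (0.20 log units; within the scatter) and so does not separate the two compounds. At this position, a six-membered aromatic ring of carbon only and a five-membered non-aromatic ring, with different counts of hydrogen-bond donors and acceptors, give values within the scatter of each other. Nothing measured here accounts for this result. Still open, from the compounds shown here alone, is how a carboxylic acid or a piperidine amide on this carbonyl carbon would compare with compound 2 and compound 4.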